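A few compounds are considered here, and "the series" means these few. Any claim that something is new, unique, unknown or untested is made for them only; others in the source may bear on it.

Measured in a functional assay on HEL cells (Homo sapiens); on this read-out higher numbers stand for lower toxicity in this test and lower numbers for higher toxicity in this test:

- Compound 1 `CCCCCCCCCCc1cc2cn(COCCO)c(O)nc-2n1`: 32000 nM
- Compound 2 `CCCCc1cc2cn(COCCO)c(=O)nc2o1`: > 200000 nM (a limit of the assay, not a number)
- Compound 3 `CCCCCCCc1cc2cn(COCCO)c(=O)nc2o1`: 140000 nM

Compound 1 has the lower of the two actual numbers, and the gap up to compound 3 lies beyond the scatter. Compound 4 `CCCCc1cc2cn(COCCO)c(O)nc-2n1` has not yet been measured. It keeps the core of compound 1 and differs by one change: hydrogen in place of hexyl on a saturated chain carbon, four bonds along the chain from an aromatic carbon, which is hydrogen in place of hexyl on a saturated chain carbon, four bonds along the chain from an aromatic carbon.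

Compounds 2 and 3 share a different core, so they are only an indirect guide. Going by the values given here, the one measured chain step is an at least 1.4-fold lower number from compound 2 to compound 3 (0.15 log units; that floor lies within the scatter), and its floor lies within the scatter. The reading for compound 2 is only a limit: the limit of > 200000 nM in this assay, at which 1 of the 3 values shown sits. Hexyl is a larger piece of chain than propyl, so a clear move to a higher number is expected, possibly reaching that limit. The expected size is an estimated step of a 4.7-fold higher number from compound 1 to compound 4 (0.67 log units; beyond the scatter). For compound 4 the estimated value is 150000 nM, with an expected range of 70000 nM to 320000 nM.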

Compound 4, half-maximal cytotoxic concentration: > 200000 nM
Compound 4: only a limit was reported; the forecaster's own chance of this, stated with the estimate: 45%; at least 1.3-fold (0.12 log units) between middle value and limit.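

The earlier chain step sat on a different core and its floor lay within the scatter, so it could only hint at what the chain does on this core. In this assay, hydrogen in place of hexyl on a saturated chain carbon, four bonds along the chain from an aromatic carbon, gives an at least 6.2-fold higher number from compound 1 to compound 4 (0.79 log units; beyond the scatter), a change beyond the scatter that shows lower toxicity in this test when the hexyl piece is absent. That step is only a floor, because compound 4 sits at a limit of the assay rather than at a number: the limit of > 200000 nM in this assay, at which 2 of the 4 values shown sit.

The compounds shown leave open at which chain length between these two the number on this core begins to fall, and whether a longer chain would lower it further. They also leave open whether an amine or a carboxylic acid in place of hexyl would read more like hydrogen or more like hexyl.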